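The source may hold more compounds than are shown below. What is called first, only, known or untested is meant among the compounds shown, and "the series" means these compounds.

Measured compounds in a physicochemical assay for solubility, in phosphate buffer, at pH 6.8; a lower number here means a less soluble compound, a higher number a more soluble compound:
Compound 1 `O=C(O)c1ccc(C(=O)C2=C(O)C(=O)N(c3ccc(-c4ccon4)cc3)C2C2CCCCC2)cc1` gives > 50000 nM in this assay, which is a limit of the assay rather than a number.
Compound 2 `COc1ccc(C(=O)C2=C(O)C(=O)N(c3ccc(-c4ccon4)cc3)C2C2CCCCC2)cn1` gives 26300 nM in this assay.
Compound 3 `Cc1cc(-c2ccc(N3C(=O)C(O)=C(C(=O)C(C)(C)C)C3c3ccccc3OCCO)cc2)on1` gives > 50000 nM in this assay, again a limit of the assay.

Compound 3 therefore stands at the upper edge of what this assay can report, where the limit of > 50000 nM in this assay, at which 2 of the 3 values shown sit, also places compound 1. For the measured compounds named here, the only step measured between two compounds is an at least 1.9-fold lower number from compound 1 to compound 2 (0.27 log units; that floor lies within the scatter), which concerns a change on the carbonyl carbon, not the aromatic position altered here, so it offers no direct guide. Compound 4 `CC(C)(C)C(=O)C1=C(O)C(=O)N(c2ccc(-c3cccs3)cc2)C1c1ccccc1OCCO` differs from compound 3 by thiophen-2-yl in place of 3-methyl-1,2-oxazol-5-yl on an aromatic carbon. Going by the values given here, with no measured step on this position, a modest drop is expected, an at least 1.6-fold lower number from compound 3 to compound 4 (0.22 log units; that floor lies within the scatter). Compound 4 is estimated at 30000 nM, between 10000 nM and 60000 nM.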

Compound 4, solubility: 38600 nM
Beside the measured number, compound 4's estimate is 1.3-fold (0.11 log units) below it, and the stated range covers the measured number.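

With thiophen-2-yl on this aromatic carbon, this assay gives the first step read at this position: an at least 1.2-fold lower number from compound 3 to compound 4 (0.11 log units; that floor lies within the scatter). Compound 4 gives a measured number, 38600 nM, so this position now has a value that later changes can be compared against. The real size of the step stays unknown because compound 3 sits at a limit of the assay: the limit of > 50000 nM in this assay, at which 2 of the 4 values shown sit.

The compounds shown leave open how an amine or a carboxylic acid on this same aromatic carbon would read in this assay. They also leave open whether this change would read the same on the core of compound 2.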